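A nitro group enters compound 3

The source may report more compounds than this note shows. Statements on the series, on what has been measured and on what is new or still open speak of the compounds shown alone.

For the measured compounds named here, in a functional assay on DU-145 cells (Homo sapiens) for cytotoxicity, read by trypan blue exclusion, with a stated time of 96 h (a lower number here means a stronger inhibitor, a higher number a weaker inhibitor), compound 3 (`COc1cc(OC)c(/C=C/S(=O)(=O)Nc2ccc(OC)c(OP(=O)(O)O)c2)c(OC)c1`) gives 40 nM, the lowest of the three numbers so far. Compound 2 (`COc1cc(OC)c(/C=C/S(=O)(=O)Nc2ccc(OC)c(F)c2)c(OC)c1`) gives 200 nM, and compound 1 (`COc1cc(OC)c(/C=C/S(=O)(=O)Nc2cc([N+](=O)[O-])c(OC)c([N+](=O)[O-])c2)c(OC)c1`) gives 10000 nM. Compound 4 (`COc1cc(OC)c(/C=C/S(=O)(=O)Nc2ccc(OC)c([N+](=O)[O-])c2)c(OC)c1`) is still unmeasured. It differs from compound 3 in one place: a group of 3 heavy atoms (1 nitrogen, 2 oxygen; no ring) in place of a group of 5 heavy atoms (4 oxygen, 1 phosphorus; no ring), on an aromatic carbon. A nitro group takes the place of a group of 5 heavy atoms, on an aromatic carbon ortho to a methoxy group.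

Going by the values given here, one measured step bears directly on this change. That step, a 5.0-fold lower number from compound 2 to compound 3 (0.70 log units; beyond the scatter), is modest and brought in the same group of 5 heavy atoms in place of one fluorine atom. Losing that group may therefore raise the number again. Compound 1 also carries nitro and sits at 10000 nM, but it differs in more than one place, so it is only a loose guide. The expected change is a rise of modest size, estimated as a 7.5-fold higher number from compound 3 to compound 4 (0.88 log units; beyond the scatter). For compound 4, the estimated value is 300 nM, with an expected range from 60 nM to 2500 nM.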

Compound 4, half-maximal inhibitory concentration: 2500 nM
For compound 4 the middle estimate is 8.3-fold (0.92 log units) below the measured one; the range from low to high includes it.
By their numbers in this assay, from the lowest: compound 3; then compound 2; then compound 4; then compound 1.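

In (this assay), this carbon proves highly sensitive to its substituent: nitro replacing the group of 5 heavy atoms is a large step (a 63-fold higher number from compound 3 to compound 4 (1.80 log units; beyond the scatter)). Nitro in place of fluoro is also a large step (a 13-fold higher number from compound 2 to compound 4 (1.10 log units; beyond the scatter)), so among the three groups seen here, the group of 5 heavy atoms gives the lowest number, fluoro the middle one and nitro the highest. Nitro is not the whole story at the high end of the series, as hydrogen in place of the second nitro of compound 1 gives a modest further change (a 4.0-fold lower number from compound 1 to compound 4 (0.60 log units; beyond the scatter)), so each added nitro on this ring goes with a higher number.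

Nothing here explains why nitro raises the number. On these data alone, it also remains open whether an amine or a hydroxyl group on this carbon would fall nearer compound 3 or compound 4.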